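Trimming a propyl chain on a scaffold showing no inhibition

The compounds below may be only part of what the source reports. "The series", "measured", "known", "first", "only" and "open" are said of these compounds alone.

Compound 1 `CCCc1nc(C)c2c(CC)nnc(S)n12` gives > 48000 nM in a functional assay for inhibition, with Homo sapiens as the target (a higher number here means a weaker inhibitor, a lower number a stronger inhibitor), which is a limit of the assay rather than a number.
Compound 2 `CCCc1ncn2c(Nc3cc[nH]n3)nccc12` gives > 48000 nM in this assay, again a limit of the assay.
Compound 3 `CCCc1nnc(S)n2c(CCC)nc(C)c12` gives > 48000 nM in this assay, once more a limit of the assay.

Compound 3 and compound 1 differ by one change, (hydrogen in place of methyl on a saturated chain carbon, two bonds along the chain from an aromatic carbon). Going by the values given here, because both values are limits, the step that the two limits leave unreadable from compound 3 to compound 1 cannot be read; the only evidence on it is the limit of > 48000 nM in this assay, at which 3 of the 3 values shown sit. Compound 2 and compound 3 share no single counted difference; the difference between the two cores is not broken down here.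

Compound 4 `CCc1ncn2c(Nc3cc[nH]n3)nccc12` is not yet measured. It differs from compound 2 by hydrogen in place of methyl on a saturated chain carbon, two bonds along the chain from an aromatic carbon, the same change as that from compound 3 to compound 1, at a place described in the same words. Among the compounds with values here, since the earlier step is unreadable and every value so far sits at the limit of this assay, nothing in these data separates the chain lengths from one another.

For compound 4 the step that the limit leaves unreadable from compound 2 to compound 4 is expected to be small, resting on the unreadable earlier step that the two limits leave unreadable from compound 3 to compound 1 and on the limit that compound 2 gives, > 48000 nM. Compound 4 is therefore estimated at 80000 nM in this assay, with a range from 30000 nM to 300000 nM, and most likely reported only as a limit.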

Compound 4, half-maximal inhibitory concentration: 36000 nM
For compound 4 the middle estimate is 2.2-fold (0.35 log units) above the measured one; the measured number falls inside the stated range.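

As far as these compounds go, on the core shared by compound 2 and compound 4, cutting propyl to ethyl gives in this assay an at least 1.3-fold lower number from compound 2 to compound 4 (0.12 log units; that floor lies within the scatter); compound 2 gives > 48000 nM, which is a limit of the assay, so this step is a floor and its full size stays unknown. What this shows is modest: on this core the change is compatible with a number that can be read, yet the floor does not establish that the ethyl compound differs from the propyl compound at all. The same change on the other core cannot be read, as both of its ends are limits, so the data do not show whether the change carries from one core to the other with a similar size, a different size or any effect, and the only evidence on that comparison is this: the limit of > 48000 nM in this assay, at which 3 of the 4 values shown sit.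

The compounds shown leave open how a methyl, a butyl chain or an amine at that same place on the core of compound 4 would read in this assay. They also leave open whether any compound on the core of compound 1 would give a number rather than a limit, which a comparison between the two cores would need.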